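The compounds below may be only part of what the source reports. "The series", "measured", "known", "first", "only" and "open" are said of these compounds alone.

Compound 1 `CCOC(=O)COc1cc(-c2cc(=O)c3c(O)cc(OCC(=O)N4CCN(Cc5ccc(OC)c(OC)c5OC)CC4)cc3o2)ccc1OC`: in an ADME assay on MRC5 cells (Homo sapiens) for cytotoxicity (on this read-out higher numbers stand for weaker inhibition and lower numbers for stronger inhibition), compound 1 gives > 70000 nM, which is a limit of the assay and not a number.
Compound 2 `COc1ccc(-c2cc(=O)c3c(O)cc(OCC(=O)N4CCN(Cc5ccc(OC)c(OC)c5OC)CC4)cc3o2)cc1OCC(=O)OC(C)(C)C`: in this assay compound 2 gives > 140000 nM, again a limit rather than a number.
Compound 3 `CCCCCCOc1cc(-c2cc(=O)c3c(O)cc(OCC(=O)N4CCN(Cc5ccc(OC)c(OC)c5OC)CC4)cc3o2)ccc1OC`: in this assay compound 3 gives "not determined" (no result reported).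

Compound 3 therefore stands nowhere on the numbers shown: it carries no value of its own, and the two compounds that share its core sit only at limits, one at the limit of > 140000 nM in this assay, at which 1 of the 3 values shown sits, and one at the limit of > 70000 nM in this assay, at which 1 of the 3 values shown sits. Among the compounds with values here, the single step among the measured compounds, a step that the two limits leave unreadable from compound 1 to compound 2, cannot be read, since both ends are limits. Compound 4 `COc1ccc(-c2cc(=O)c3c(O)cc(OCC(=O)N4CCN(Cc5ccc(OC)c(OC)c5OC)CC4)cc3o2)cc1OC1CCCC1` differs from compound 3 by cyclopentyl in place of hexyl on an oxygen on an aromatic ring. Within the data shown here, no measured step touches an oxygen on an aromatic ring of this kind, so nothing here tells whether this change moves the read-out in either direction beyond the scatter. Given that every reported value in this assay is a limit, compound 4 is expected to sit in the same region, estimated at 100000 nM with a range from 30000 nM to 300000 nM, and most likely to be reported again only as a limit.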

Compound 4, half-maximal inhibitory concentration: > 150000 nM
Compound 4: only a limit was reported; the forecaster's own chance of this, stated with the estimate: 80%; middle value at least 1.5-fold (0.17 log units) away from the limit.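

The steps from compound 1 to compound 4 and from compound 2 to compound 4 cannot be read: all three compounds stand only at limits in this assay. The compounds shown leave open how far apart these three truly lie, and where compound 3 stands.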